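Half-life notes on the aryl swap at the chain carbon

The source may report more compounds than this note shows. Statements on the series, on what has been measured and on what is new or still open speak of the compounds shown alone.

Measured in an ADME assay on microsomes from liver (Homo sapiens) for metabolic stability, read by LC-MS, using NADPH, tested at 3 uM; a higher number here means that the compound lasts longer, a lower number that the compound disappears faster:
- compound 1 `FC(F)(F)CC(c1ccco1)c1c(-c2ccccc2)[nH]c2cc(Cl)ccc12`: 1.07 h
- compound 2 `FC(F)(F)CC(c1cccs1)c1c(-c2ccccc2)[nH]c2cc(Cl)ccc12`: 2.62 h

For the measured compounds named here, of the two numbers so far, the higher belongs to compound 2 at 2.62 h, and the gap to compound 1 lies beyond the scatter. The next structure is compound 3 `FC(F)(F)CC(c1ccccc1)c1c(-c2ccccc2)[nH]c2cc(Cl)ccc12`, with phenyl in place of thiophen-2-yl on a saturated chain carbon bound to an aromatic carbon and a saturated chain carbon. Going by the values given here, one measured step bears on this, made at the same place: a 2.4-fold higher number from compound 1 to compound 2 (0.39 log units; beyond the scatter), a modest change. That step involves no phenyl, so it gives only a rough size and no firm direction. In this assay, no change beyond the scatter is expected, though a step of that modest size in either direction remains possible. The expected step is a 1.1-fold higher number from compound 2 to compound 3 (0.06 log units; within the scatter). For compound 3 the estimated half-life is 3 h, with an expected range of 1.4 h to 6.5 h.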

Compound 3, half-life: 1.64 h
Compound 3: the middle estimate sits 1.8-fold (0.26 log units) above what was measured; the range from low to high includes it.
By their numbers in this assay, from the lowest: compounds 1, 3 and 2 (each within the scatter of the next, the first and the last beyond it).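

In this assay, phenyl on the saturated chain carbon gives a 1.6-fold lower number from compound 2 to compound 3 (0.20 log units; within the scatter) and a 1.5-fold higher number from compound 1 to compound 3 (0.19 log units; within the scatter), so neither step separates it from the five-membered aromatic rings. The six-membered aromatic ring of carbon only, with no hydrogen-bond acceptor, therefore shows no half-life distinct from either neighbour, and the one gap beyond the scatter at this place remains that between thiophen-2-yl and furan-2-yl. Nothing available accounts for these half-lives or says how the compounds are lost in the assay.

Still open, on these data alone, is how the half-life responds at this chain carbon to a pyridin-2-yl ring or to a non-aromatic group such as an amine or a carboxylic acid. Also open, as far as these compounds go, is whether these small steps hold with a different group elsewhere on the shared core.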